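This account rests on a few compounds, and the source may have more. Where it says the series, first, only, none or still open, it means among the compounds named here.

Compound 2 `Cc1nc(C)c([C@H](OC(C)(C)C)C(=O)O)c(N2CCC(C)(C)CC2)c1-c1ccc(OCCc2ccc(F)c(F)c2)cc1` belongs to a set of three measured compounds that share one core and differ only in the group on a saturated chain carbon, two bonds along the chain from an oxygen on an aromatic ring. In a toxicity assay on MT2 cells (Homo sapiens) for cytotoxicity, read by XTT assay, with a stated time of 4 days (on this read-out higher numbers stand for lower toxicity in this test and lower numbers for higher toxicity in this test), compound 2 gives >= 33500 nM, which is a limit of the test rather than a number. Compound 1 `Cc1nc(C)c([C@H](OC(C)(C)C)C(=O)O)c(N2CCC(C)(C)CC2)c1-c1ccc(OCCc2ccc(Cl)cc2)cc1`, carrying 4-chlorophenyl in that place, gives >= 33500 nM in this assay, again only a limit. Compound 3 `Cc1nc(C)c([C@H](OC(C)(C)C)C(=O)O)c(N2CCC(C)(C)CC2)c1-c1ccc(OC2COCC2c2ccc(F)cc2)cc1` gives >= 32000 nM; >= 32000 nM (2 entries) in this assay, also a limit. Compound 2 therefore stands where every measured compound stands, at the edge of what the test can report, and the step that the two limits leave unreadable from compound 1 to compound 2 cannot be read because of the limit of >= 33500 nM in this assay, at which 2 of the 3 values shown sit.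

Compound 4 `Cc1ccc(CCOc2ccc(-c3c(C)nc(C)c([C@H](OC(C)(C)C)C(=O)O)c3N3CCC(C)(C)CC3)cc2)s1` has not yet been measured. It differs from compound 2 in a single place: 5-methylthiophen-2-yl in place of 3,4-difluorophenyl on a saturated chain carbon, two bonds along the chain from an oxygen on an aromatic ring. For the measured compounds named here, the only measured step touching this place is the one from compound 1 to compound 2, and its size is unreadable, so no direction can be drawn from it; every measured compound sits at a limit. The expected step of a number no higher from compound 2 to compound 4 (the limit leaves the size open) is therefore none beyond the scatter, with a limit again the most likely outcome. Compound 4 is expected to give about 33500 nM, within 20000 nM to 60000 nM, in this assay.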

Compound 4, half-maximal cytotoxic concentration: >= 25000 nM
Compound 4 gave a limit, no number (the forecaster's own chance of this, stated with the estimate: 85%); the middle value lies beyond the limit too.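

In this assay compound 4 gives >= 25000 nM, which is a limit of the test and not a number. Compound 1 and compound 2 also give only limits, so the steps from each of them to compound 4 cannot be read. The compounds shown leave open whether the group in this place affects toxicity in this test at all.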